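Lengthening a Chain One Carbon at a Time

The source may hold more compounds than are shown below. What is called first, only, known or untested is meant among the compounds shown, and "the series" means these compounds.

Compound 2 `CCCOC(=O)N1CCN(/[N+]([O-])=N/Oc2cc(O/N=[N+](\[O-])N(C)C)c([N+](=O)[O-])cc2[N+](=O)[O-])CC1` gives 1600 nM in a functional assay on HL-60 cells (Homo sapiens) for antiproliferative activity, read by MTT assay, with a stated time of 72 h; on this read-out lower numbers stand for stronger inhibition and higher numbers for weaker inhibition. Its companion compound 1 `CCOC(=O)N1CCN(/[N+]([O-])=N/Oc2cc(O/N=[N+](\[O-])N(C)C)c([N+](=O)[O-])cc2[N+](=O)[O-])CC1` gives 1200 nM in this assay, and the two values lie within the usual scatter of one another, so nothing separates them on the numbers shown. Among the measured compounds shown here, the one step recorded so far, a 1.3-fold higher number from compound 1 to compound 2 (0.12 log units; within the scatter), is the same kind of change that now leads to compound 3 `CCCCOC(=O)N1CCN(/[N+]([O-])=N/Oc2cc(O/N=[N+](\[O-])N(C)C)c([N+](=O)[O-])cc2[N+](=O)[O-])CC1`: methyl in place of hydrogen on a saturated chain carbon, three bonds along the chain from an oxygen next to a carbonyl group. That earlier step moved the number only within the scatter, and the present change repeats it one bond further out along the same chain, so no step beyond the scatter is expected in this assay. The estimated step is a 1.1-fold higher number from compound 2 to compound 3 (0.05 log units; within the scatter). Compound 3 is therefore expected to give about 1800 nM in this assay, with a likely range from 900 nM to 3600 nM.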

Compound 3, half-maximal inhibitory concentration: 900 nM
Compound 3: middle estimate off by 2.0-fold (0.30 log units), on the high side, and the stated range covers the measured number.
By their numbers in this assay, from the lowest: compounds 3, 1 and 2 (each within the scatter of the next).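

In this assay the change from propyl to butyl gives a 1.8-fold lower number from compound 2 to compound 3 (0.25 log units; within the scatter) and the passage from ethyl to butyl gives a 1.3-fold lower number from compound 1 to compound 3 (0.12 log units; within the scatter) so this second extension of the chain, like the first, stays within the scatter. Taken together with the earlier step, the ethyl, propyl and butyl chains cannot be told apart on these numbers, and the series shows no trend with chain length across compound 1, compound 2 and compound 3. Nothing available bears on this result.

The compounds shown leave open whether a longer chain such as hexyl or octyl would stay within the same scatter. From the compounds shown here alone, it is equally open whether a branched group such as isopropyl or tert-butyl, or a chain ending in an amine or a carboxylic acid, would move the number beyond it.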